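Cytotoxicity notes: compounds 1 to 4

The source may hold more compounds than are shown below. What is called first, only, known or untested is meant among the compounds shown, and "the series" means these compounds.

Measured so far:
compound 1 `Cc1cn(CCCCCOc2ccc(Br)cc2)c(=O)[nH]c1=O`: 100000 nM
compound 2 `O=c1ccn(CCCCOc2ccc(Br)cc2)c(=O)[nH]1`: 100000 nM
compound 3 `N#Cc1ccc(OCCCCCn2ccc(=O)[nH]c2=O)cc1`: 100000 nM

In an ADME assay on HEL cells (Homo sapiens) for cytotoxicity, read by microscopy (on this read-out lower numbers stand for higher toxicity in this test and higher numbers for lower toxicity in this test), compound 3 gives 100000 nM, level with compounds 1 and 2 at the digits shown; the values of compound 1 and compound 2 lie within the scatter of it, so no order among the three can be read.

Compound 4 `O=C(O)c1ccc(OCCCCCn2ccc(=O)[nH]c2=O)cc1` differs from compound 3 by carboxy in place of cyano on an aromatic carbon, on an aromatic carbon of a six-membered aromatic ring of carbon only, para to a large group.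

Among the measured compounds shown here, no step between measured compounds has been determined. Given that compound 3 sits at 100000 nM and compounds 1 and 2 sit at the same figure, no change beyond the scatter is expected in this assay for compound 4; the expected step is no change at the digits printed from compound 3 to compound 4 (within the scatter). Compound 4 is estimated at 100000 nM, range 50000 nM to 200000 nM.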

Compound 4, minimum cytotoxic concentration: > 100000 nM
Compound 4: no number, only a limit; the forecaster's own chance of this, stated with the estimate: 35%; the middle value lies on the limit itself.
By their numbers in this assay, from the lowest: compounds 1, 2 and 3 (each within the scatter of the next).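

In this assay compound 4 gives > 100000 nM, which is a limit and not a number. Carboxy in place of cyano on the aromatic carbon para to a large group gives a number no lower from compound 3 to compound 4 (the limit leaves the size open), the first step read at this position, and it adds a hydrogen-bond donor there without a lower number in this test. This is the only limit among the values shown: the limit of > 100000 nM in this assay, at which 1 of the 4 values shown sits.

As far as these compounds go, the size of the step stays unknown. Also open, from the compounds shown here alone, is whether an amine or a methyl ester at this position would give a lower number.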